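This account rests on a few compounds, and the source may have more. Where it says the series, first, only, none or still open, it means among the compounds named here.

Compound 1 `N=C(S)CCn1ncccc1=O` was tested in a functional assay on the whole organism (stomach) with Rattus norvegicus as the target; a lower number here means that less compound is needed, a higher number that more compound is needed for the effect. In this assay compound 1 reaches only the limit of the assay, > 100 mg/kg, so no number is known for it. Compound 2 `C/N=C(\S)CCn1ncccc1=O` differs from compound 1 by a group of 4 heavy atoms (2 carbon, 1 nitrogen, 1 sulfur; no ring) in place of a group of 3 heavy atoms (1 carbon, 1 nitrogen, 1 sulfur; no ring), on a saturated chain carbon, two bonds along the chain from an aromatic nitrogen. In this assay compound 2 also gives only the limit, > 100 mg/kg. The step that the two limits leave unreadable from compound 1 to compound 2 therefore cannot be read, and the limit of > 100 mg/kg in this assay, at which 2 of the 2 values shown sit, is all the measurements offer.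

Compound 3 `Cc1ccc(=O)n(CCC(=N)S)n1` is not yet measured. Its change from compound 1 is methyl in place of hydrogen on an aromatic carbon. Going by the values given here, the only measured step, a step that the two limits leave unreadable from compound 1 to compound 2, concerns a different part of the molecule and is itself unreadable, so it does not bear on this change, and there is no basis to expect a step of any size or direction beyond the scatter. Compound 3 is therefore expected to give 150 mg/kg, within a range from 50 mg/kg to 500 mg/kg, most likely again as a limit. The expected step is a step that the limit leaves unreadable from compound 1 to compound 3.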

Compound 3, dose for half-maximal effect: 43.2 mg/kg
Compound 3: middle estimate off by 3.5-fold (0.54 log units), on the high side; measured number below the stated range.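

Methyl in place of hydrogen on an aromatic carbon is the first change in this series whose effect can be read in this assay: it gives an at least 2.3-fold lower number from compound 1 to compound 3 (0.36 log units; beyond the scatter) and so shows that less compound is needed for the effect. This part of the ring therefore responds to the addition of a single methyl group, something the earlier pair could not show, as its change lay on the chain and its step cannot be read. The step is only a lower bound on the real difference, since it starts from a limit and not from a number: the limit of > 100 mg/kg in this assay, at which 2 of the 3 values shown sit.

Still open, on these data alone, is whether this effect belongs to methyl alone or would also appear with a longer group such as ethyl, or with a chlorine atom or a methoxy group, on the same carbon. Also open, as far as these compounds go, is how methyl would act on the other ring carbons, and whether the chain change that separates compound 2 from compound 1 would give a readable step with the methyl group in place.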